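The compounds below may be only part of what the source reports. "The series", "measured", "known", "first", "only" and "open" are said of these compounds alone.

Compound 1 `O=[N+]([O-])c1cc(CSc2nnnn2Cc2ccccc2)cc([N+](=O)[O-])c1` gives > 30000 nM in an ADME assay on MDCK-II cells (Canis lupus familiaris) for cytotoxicity, read by MTT assay, with a stated time of 48 h (on this read-out lower numbers stand for stronger inhibition and higher numbers for weaker inhibition), which is a limit of the assay and not a number.
Compound 2 `O=[N+]([O-])c1cc(CSc2nnnn2C2CCCCC2)cc([N+](=O)[O-])c1` gives > 30000 nM in this assay, again a limit.
Within the data shown here, compound 3 `O=[N+]([O-])c1cc(C[Se]c2nnnn2Cc2ccccc2)cc([N+](=O)[O-])c1` gives 22000 nM in this assay, the only number among the three.

The change from compound 1 to compound 2 is cyclohexyl in place of benzyl on an aromatic nitrogen. Its step, a step that the two limits leave unreadable from compound 1 to compound 2, has no readable size because both values sit at the limit of > 30000 nM in this assay, at which 2 of the 3 values shown sit.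

Compound 4 `O=[N+]([O-])c1cc(C[Se]c2nnnn2C2CCCCC2)cc([N+](=O)[O-])c1` has not yet been measured. It differs from compound 3 by cyclohexyl in place of benzyl on an aromatic nitrogen, the same change as that from compound 1 to compound 2. How the core of compound 3 differs from the core of compound 1 is not broken down here. Among the measured compounds shown here, since the one measured instance of this change gives no readable size, the step expected from compound 3 to compound 4, a 1.1-fold higher number from compound 3 to compound 4 (0.06 log units; within the scatter), is taken as small and rests on compound 3 giving 22000 nM. For compound 4 the estimate in this assay is 25000 nM, expected between 10000 nM and 60000 nM, with a sizeable chance that only a limit is reported.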

Compound 4, half-maximal inhibitory concentration: 19000 nM
Compound 4: the middle estimate sits 1.3-fold (0.12 log units) above what was measured, and the stated range covers the measured number.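

On the core of compound 3, cyclohexyl in place of benzyl on an aromatic nitrogen gives a 1.2-fold lower number from compound 3 to compound 4 (0.06 log units; within the scatter) in this assay, so this exchange leaves the read-out on that core unresolved from the scatter. On the core of compound 1 the same exchange cannot be read, as both values there are limits of the assay and not numbers: the limit of > 30000 nM in this assay, at which 2 of the 4 values shown sit. This leaves a single readable instance of the change, which shows that it has no sizeable effect on one core but does not show that the same holds on the other, and no two step sizes can be compared.

The compounds shown leave open whether a different group on that aromatic nitrogen, such as a longer chain, an amine or a carboxylic acid, would give a step beyond the scatter. Among these compounds, how the two cores compare with the same group in place also stays open, as no step between them can be read here.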